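Cycloheptyl to Difluorophenyl: Expected Cytotoxicity of Compound 3

A few compounds are considered here, and "the series" means these few. Any claim that something is new, unique, unknown or untested is made for them only; others in the source may bear on it.

Compound 2 `Cc1nc(C(NC(=O)C(=O)NC2CCCCCC2)C2CCCCN2)sc1CCO` was examined in an ADME assay on TZM-b1 cells (Homo sapiens) for cytotoxicity, read by XTT assay, with a stated time of 3 days; on this read-out lower numbers stand for higher toxicity in this test and higher numbers for lower toxicity in this test. Compound 2 reached only the limit of the test, > 88000 nM, as recorded under (the limit of > 88000 nM in this assay, at which 1 of the 2 values shown sits). Compound 1 `Cc1nc(C(NC(=O)C(=O)Nc2ccc(F)c(F)c2)C2CCCCN2)sc1CO` likewise gave only a limit, > 87000 nM, noted under (the limit of > 87000 nM in this assay, at which 1 of the 2 values shown sits). Neither measured value is therefore a number, and compound 2 sits at one of these two limits. Compound 3 `Cc1nc(C(NC(=O)C(=O)Nc2ccc(F)c(F)c2)C2CCCCN2)sc1CCO` has not been measured; it differs from compound 2 by 3,4-difluorophenyl in place of cycloheptyl on an amide-type nitrogen. Going by the values given here, no step of this kind has been measured, so the change is expected to stay within the scatter, a step that the limit leaves unreadable from compound 2 to compound 3, with a limit again the most likely outcome. Compound 3 is accordingly estimated to give 100000 nM in this assay, within 60000 nM to 200000 nM.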

Compound 3, half-maximal cytotoxic concentration: > 78200 nM
Compound 3: no number, only a limit; the forecaster's own chance of this, stated with the estimate: 85%; the middle value lies beyond the limit too.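

In this assay compound 3 gives > 78200 nM, which is a limit and not a number. Going by these compounds alone, compound 1 and compound 2 also gave only limits, so no step to compound 3 can be read. The compounds shown leave open whether either change affects cytotoxicity at all.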